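Cytotoxicity notes: amide side chain swap on compound 3

A few compounds are considered here, and "the series" means these few. Any claim that something is new, unique, unknown or untested is made for them only; others in the source may bear on it.

Measured compounds:
compound 1, `CC1=NN(C(=O)CCl)C(c2cc(Br)ccc2O)C1`, 16300 nM
compound 2, `CC1=NN(S(=O)(=O)c2ccc(C)cc2)C(c2cc(Br)ccc2O)C1`, 20800 nM
compound 3, `CNCC(=O)N1N=C(c2cc3ccccc3oc2=O)CC1c1ccccc1`, 24000 nM

All three numbers come from a functional assay on HepG2 cells (Homo sapiens) for cytotoxicity, read by MTT assay, with a stated time of 48 h; on this read-out higher numbers stand for weaker inhibition and lower numbers for stronger inhibition. Compound 3 gives 24000 nM; the gap to compound 2 and the gap to compound 1 both lie within the usual scatter, so the three compounds cannot be told apart on this read-out.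

Compound 4, `CN1CCN(CC(=O)N2N=C(c3cc4ccccc4oc3=O)CC2c2ccccc2)CC1`, keeps the core of compound 3 and differs only at the amide side chain: 4-methylpiperazin-1-yl in place of methylamino on a saturated chain carbon bound to a carbonyl carbon. Among the measured compounds shown here, no measured pair in the set isolates this kind of change, so nothing in the data points to a shift in either direction. The expectation for compound 4 is therefore a number close to that of compound 3, with the step of no change at the digits printed from compound 3 to compound 4 (within the scatter) expected to stay within the scatter. Compound 4 is estimated at 24000 nM, with a range from 10000 nM to 55000 nM.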

Compound 4, half-maximal inhibitory concentration: 33100 nM
Estimate against measurement, compound 4: 1.4-fold (0.14 log units) below; the measured number falls inside the stated range.
By their numbers in this assay, from the lowest: compounds 1, 2, 3 and 4 (each within the scatter of the next, the first and the last beyond it).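

In this assay, 4-methylpiperazin-1-yl in place of methylamino on a saturated chain carbon bound to a carbonyl carbon gives a 1.4-fold higher number from compound 3 to compound 4 (0.14 log units; within the scatter). This position therefore tolerates a larger group with a six-membered non-aromatic ring and no hydrogen-bond donor, with no step beyond the scatter on this read-out. No available evidence bears on the origin of this small step.

On these data alone, whether a carboxylic acid or a longer chain carrying the amine would move the number beyond the scatter remains open. Also open, as far as these compounds go, is whether the same swap behaves alike on another core.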